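Lengthening the Hydroxycarbamoyl Chain Beyond Compound 2

The compounds below may be only part of what the source reports. "The series", "measured", "known", "first", "only" and "open" are said of these compounds alone.

Measured so far in a functional assay on PC-3 cells (Homo sapiens) for inhibition, read by sulforhodamine B assay, with a stated time of 48 h; a lower number here means a stronger inhibitor, a higher number a weaker inhibitor:
- compound 1 (`O=C(Nc1ccc(C(=O)NO)cc1)Nc1ccc(Cl)c(C(F)(F)F)c1`) gives 3100 nM as its value
- compound 2 (`O=C(CCCC(=O)Nc1ccc(NC(=O)Nc2ccc(Cl)c(C(F)(F)F)c2)cc1)NO`) gives > 10000 nM as a limit, not a number

Compound 2 has only a limit and no number in this assay (the limit of > 10000 nM in this assay, at which 1 of the 2 values shown sits). The next structure, compound 3 (`O=C(CCCCCCC(=O)Nc1ccc(NC(=O)Nc2ccc(Cl)c(C(F)(F)F)c2)cc1)NO`), has 3-(hydroxycarbamoyl)propyl in place of hydroxycarbamoyl on a saturated chain carbon, three bonds along the chain from a carbonyl carbon. Among the measured compounds shown here, only one measured step bears on this change, and only indirectly. That step is an at least 3.2-fold higher number from compound 1 to compound 2 (0.50 log units; beyond the scatter), and it too placed a chain in front of the hydroxycarbamoyl group. For the measured compounds named here, its size is a lower bound rather than an exact figure, and no measured step shows what a longer chain does once a chain is already there. Compound 3 is therefore expected to stay in the same weak region as compound 2, with no confident call of a change beyond the scatter in either direction. The estimated change is an at least 1.1-fold lower number from compound 2 to compound 3 (0.04 log units; that floor lies within the scatter) in this assay and remains loose. The estimate for compound 3 is 9000 nM as the expected value, with 2500 nM to 30000 nM as its expected range.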

Compound 3, half-maximal inhibitory concentration: 4600 nM
Beside the measured number, compound 3's estimate is 2.0-fold (0.29 log units) above it, and the stated range covers the measured number.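

The earlier step, which placed a chain in front of the hydroxycarbamoyl group, could only show that the number rose, so nothing yet showed what chain length does once a chain is present. In this assay, putting 3-(hydroxycarbamoyl)propyl in place of hydroxycarbamoyl on a saturated chain carbon, three bonds along the chain from a carbonyl carbon, gives an at least 2.1-fold lower number from compound 2 to compound 3 (0.33 log units; beyond the scatter), which shows that length alone changes the result at this position and that lengthening an existing chain moves the number the opposite way from adding the first one. That size is a floor rather than an exact figure, since compound 2 carries a limit and not a number: the limit of > 10000 nM in this assay, at which 1 of the 3 values shown sits.

Among the compounds shown here, two compounds with a chain give only one comparison of length, so it remains unknown whether a longer chain would lower the number further or raise it again. On these data alone, what a carboxylic acid or an amine would give in place of the hydroxycarbamoyl group at the end of this chain also remains unknown, so these results cannot say whether that end group is needed.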